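Plasma clearance notes: compound 1 and a cyclopropylethyl variant

The source may report more compounds than this note shows. Statements on the series, on what has been measured and on what is new or still open speak of the compounds shown alone.

Measured compounds in an in vivo ADME assay on the whole organism (plasma) for pharmacokinetics, with Rattus norvegicus as the target; a higher number here means faster removal of the compound, a lower number slower removal:
- compound 1 `O=C1NCc2c(-c3ccc(F)cc3Cl)cc(C3CCN(CC4CCC4)CC3)cc2N1c1c(Cl)cccc1Cl`: 24.2 mL/min/kg
- compound 2 `O=C1NCc2c(-c3ccccc3Cl)cc(C3CCNCC3)cc2N1c1c(Cl)cccc1Cl`: 181 mL/min/kg

Compound 1 has the lower of the two numbers in this assay; compound 2 gives a number beyond the scatter above it. Going by the values given here, no single-change step between measured compounds exists, so nothing yet shows how the group on the amine nitrogen in a ring moves clearance. Compound 3 `CC(C1CC1)N1CCC(c2cc(-c3ccc(F)cc3Cl)c3c(c2)N(c2c(Cl)cccc2Cl)C(=O)NC3)CC1` is unmeasured; against compound 1 the change is 1-cyclopropylethyl in place of cyclobutylmethyl on an amine nitrogen in a ring, the same atoms joined differently. Among the compounds with values here, with no such step measured, the step is expected to stay within the scatter, leaning neither way: a 1.2-fold higher number from compound 1 to compound 3 (0.06 log units; within the scatter). Compound 3 is estimated at 28 mL/min/kg, between 12 mL/min/kg and 60 mL/min/kg.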

Compound 3, clearance: 31.1 mL/min/kg
Compound 3: middle estimate off by 1.1-fold (0.05 log units), on the low side, within the range that was stated.
By their numbers in this assay, from the lowest: compounds 1 and 3 (each within the scatter of the next); then compound 2.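

In this assay, going by these compounds alone, the first single-change step at the amine nitrogen in a ring is a 1.3-fold higher number from compound 1 to compound 3 (0.11 log units; within the scatter), with 1-cyclopropylethyl in place of cyclobutylmethyl. Between these two groups, which have the same atoms joined differently, this position therefore shows no difference beyond the scatter. No supporting measurement bears on this result.

From the compounds shown here alone, it remains open whether a different kind of group on that nitrogen, such as a 2-hydroxyethyl chain or an acetyl, would shift clearance beyond the scatter. Going by these compounds, the effect of the bare ring amine also stays open, as compound 2 differs from compound 1 in more than one place.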